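Swapping a pyridinyloxy for a cyanophenyl on a piperidine urea

A few compounds are considered here, and "the series" means these few. Any claim that something is new, unique, unknown or untested is made for them only; others in the source may bear on it.

Measured compounds:
compound 1, `O=C(Nc1cc(-c2ccccn2)n[nH]1)N1CCC(Oc2ccccn2)CC1`, < 11.9 mL.min-1.g-1
compound 2, `O=C(Nc1cc(-c2ccccn2)n[nH]1)N1CCN(c2ccc(F)cc2)CC1`, 30.8 mL.min-1.g-1
compound 3, `O=C(NCc1cccc(Cl)c1)Nc1cc(-c2ccccn2)n[nH]1`, 184 mL.min-1.g-1

All three share the same core, a pyrazole bearing a pyridine and a urea, and differ only in the group hung on the other side of the urea. They were tested in an ADME assay on liver for metabolic stability, with Liver microsome (Homo sapiens) as the target, using microsomes; a higher number here means faster removal of the compound, a lower number slower removal. Compound 1 gives < 11.9 mL.min-1.g-1, and this is a limit of the assay rather than a measured number. Compound 1 therefore stands at the limit of < 11.9 mL.min-1.g-1 in this assay, at which 1 of the 3 values shown sits. In this assay compound 2 gives 30.8 mL.min-1.g-1, and compound 3 gives 184 mL.min-1.g-1, the highest of the three numbers shown.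

The new compound is compound 4, `N#Cc1ccc(C2CCN(C(=O)Nc3cc(-c4ccccn4)n[nH]3)CC2)cc1`. It differs from compound 1 in one place:

4-cyanophenyl in place of (pyridin-2-yl)oxy on a saturated ring carbon

For the measured compounds named here, no pair of measured compounds differing in a single place is available, so the size of this step cannot be read from a neighbouring example. The three values together show that changing this side group can shift the read-out across a wide span, with compound 1 at the slow end and compound 3 at the fast end. For compound 4 the step of an at least 2.1-fold higher number from compound 1 to compound 4 (0.32 log units; beyond the scatter) is expected to be modest, toward faster removal. The estimate for compound 4 is 25 mL.min-1.g-1, with a likely range from 10 mL.min-1.g-1 to 65 mL.min-1.g-1.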

Compound 4, intrinsic clearance in microsomes: 25.3 mL.min-1.g-1
Compound 4: the middle estimate sits 1.0-fold (0.01 log units) below what was measured, and the stated range covers the measured number.
By their numbers in this assay, from the lowest: compounds 4 and 2 (each within the scatter of the next); then compound 3. At a limit, below all of these: compound 1.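

In this assay, putting 4-cyanophenyl in place of (pyridin-2-yl)oxy on the saturated ring carbon gives an at least 2.1-fold higher number from compound 1 to compound 4 (0.32 log units; beyond the scatter). For the compounds shown here, this is the first direct one-place comparison here, and it shows that the group on this carbon of the piperidine ring can by itself move the rate of removal in microsomes by more than the usual scatter. The size of that move is only a minimum, since the figure for compound 1 is a limit of the assay and not a number: the limit of < 11.9 mL.min-1.g-1 in this assay, at which 1 of the 4 values shown sits.

The swap changes several things at once: the oxygen goes, the ring nitrogen goes, and a nitrile arrives, so the compounds shown cannot say which of these parts accounts for the step. A plain phenyl or a phenoxy group on the same carbon would begin to separate these parts, while an amine or a carboxylic acid in place of the nitrile would show whether this end of the group matters at all for the rate of removal.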